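Cytotoxicity notes: from dimethylamino to pyrrolidin-1-yl

The compounds below may be only part of what the source reports. "The series", "measured", "known", "first", "only" and "open" are said of these compounds alone.

Measured in an ADME assay on L6 cells (Rattus norvegicus) for cytotoxicity (on this read-out higher numbers stand for weaker inhibition and lower numbers for stronger inhibition), so far:
- compound 1 `O=C1CC2(N3CCCC3)CC(c3ccccc3)C1C(c1ccccc1)C2` gives 26500 nM
- compound 2 `COc1ccc(C2CC3(N(C)C)CC(O)C2C(c2ccc(OC)cc2)C3)cc1` gives 63400 nM

Compound 2 holds the higher of the two numbers, and its gap to compound 1 lies beyond the usual scatter. It is therefore the weaker inhibitor of the pair. Compound 3 `COc1ccc(C2CC3(N4CCCC4)CC(O)C2C(c2ccc(OC)cc2)C3)cc1` is the next to be read. It carries pyrrolidin-1-yl in place of dimethylamino on a saturated ring carbon of compound 2 pyrrolidin-1-yl in place of dimethylamino on a saturated ring carbon and is otherwise unchanged.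

Among the compounds with values here, no measured pair differs in one place only, so the series offers no direct precedent for this swap. Within the data shown here, the one hint is that compound 1 also carries pyrrolidin-1-yl and gives 26500 nM in this assay, yet it differs from compound 2 elsewhere as well. A small move toward a lower number is therefore expected, possibly none beyond the scatter. The expected change a 1.4-fold lower number from compound 2 to compound 3 (0.15 log units; within the scatter) is a tentative figure. For compound 3 the estimated value is 45000 nM, with an expected range from 18000 nM to 100000 nM in this assay.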

Compound 3, half-maximal inhibitory concentration: 17900 nM
Beside the measured number, compound 3's estimate is 2.5-fold (0.40 log units) above it, outside the stated range (below it).
By their numbers in this assay, from the lowest: compounds 3 and 1 (each within the scatter of the next); then compound 2.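

In this assay, within the data shown here, pyrrolidin-1-yl in place of dimethylamino on the saturated ring carbon gives a 3.5-fold lower number from compound 2 to compound 3 (0.55 log units; beyond the scatter), the only single-place step so far, so this change can now be read without other differences in the core. The position is therefore not silent in this read-out: replacing the open dimethylamino group with a five-membered non-aromatic ring, with the hydroxy group and the rest of compound 3 otherwise matching compound 2, goes with stronger inhibition of modest size, although a single step sets no trend. No measurement shown here explains the shift.

Open, on these data alone, is whether the direction holds for other amines on this carbon, such as piperidin-1-yl, morpholin-4-yl or a plain primary amine, which would show whether the ring itself or simply the larger group tracks with the lower number. Also open is whether the same swap gives a similar step on the core of compound 1, which carries a carbonyl and unsubstituted phenyl groups, since no dimethylamino partner of compound 1 is among the compounds shown.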